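The compounds below may be only part of what the source reports. "The series", "measured", "known", "first", "only" and "open" are said of these compounds alone.

Measured so far in a functional assay on MCF7 cells (Homo sapiens) for cytotoxicity, read by MTT assay, with a stated time of 48 h; on this read-out lower numbers stand for stronger inhibition and higher numbers for weaker inhibition:
compound 1, `COc1ccc(C2CC(c3ccccc3)=Nc3c(C)noc3C2C(c2ccccc2)C2c3onc(C)c3N=C(c3ccccc3)CC2c2ccc(OC)cc2)cc1`, 53.8 ug/mL
compound 2, `Cc1noc2c1N=C(c1ccccc1)CC(c1ccccc1)C2C(c1ccccc1)C1c2onc(C)c2N=C(c2ccccc2)CC1c1ccccc1`, 68.9 ug/mL

Compound 2 sits at one end of these two numbers, but its gap to compound 1 lies within the usual scatter, so the two values cannot be told apart. Compound 3, `Cc1noc2c1N=C(c1ccccc1)CC(c1ccccc1)C2C(c1ccc(Cl)cc1)C1c2onc(C)c2N=C(c2ccccc2)CC1c1ccccc1`, has not been measured. Against compound 2 the difference is chloro in place of hydrogen on an aromatic carbon. Going by the values given here, no comparison of measured compounds isolates this change, so there is nothing to scale from. The step from compound 2 to compound 3 in this assay is expected to be small, within or barely beyond the scatter, as a 1.2-fold lower number from compound 2 to compound 3 (0.07 log units; within the scatter). For compound 3 the estimate in this assay is 58 ug/mL, with a range of 32 ug/mL to 105 ug/mL.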

Compound 3, half-maximal inhibitory concentration: 59 ug/mL
Compound 3: the middle estimate sits 1.0-fold (0.01 log units) below what was measured; measured number inside the range.
By their numbers in this assay, from the lowest: compounds 1, 3 and 2 (each within the scatter of the next).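

In this assay, going by these compounds alone, chloro in place of hydrogen on an aromatic carbon, para to a large group, gives a 1.2-fold lower number from compound 2 to compound 3 (0.07 log units; within the scatter), the first step that isolates a single change. At this position, phenyl to 4-chlorophenyl therefore leaves the value within the scatter. No measurement shown accounts for this outcome.

Going by these compounds, whether an amine or a carboxylic acid at this position would move the number beyond the scatter remains open. So does the effect of chloro on the other aromatic rings of the shared core.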